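Urea series: inhibition of PC-9 cells, next anilide variant

This account rests on a few compounds, and the source may have more. Where it says the series, first, only, none or still open, it means among the compounds named here.

Measured so far:
- compound 1 `COc1cc(NC(=O)Nc2cc(Nc3ccc(C)c(C)c3)ncn2)cc(OC)c1` — 66%
- compound 2 `COc1ccc(Nc2cc(NC(=O)Nc3c(Cl)cccc3Cl)ncn2)cc1C` — 80.1%
- compound 3 `COc1ccc(C(F)(F)F)cc1Nc1cc(NC(=O)Nc2c(Cl)cccc2Cl)ncn1` — 89%

In a functional assay on PC-9 cells (Homo sapiens) for inhibition, read by MTT assay, with a stated time of 48 h, tested at 10 uM (a lower number here means less inhibition, a higher number more inhibition at the concentration tested (going by the name of the read-out)), compound 1 gives 66%, the lowest of the three numbers; compound 2 stands higher by more than the scatter, and compound 3 higher still. For the measured compounds named here, compounds 2 and 3 differ from compound 1 in more than one place, so their values show only that the number in this assay is higher for each of them than for compound 1.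

Compound 4 `COc1cc(NC(=O)Nc2cc(Nc3ccc(Br)cc3OC)ncn2)cc(OC)c1` is not yet measured. It changes compound 1 by 4-bromo-2-methoxyphenyl in place of 3,4-dimethylphenyl on a nitrogen on an aromatic ring. Going by the values given here, no step for this exact change exists among the measured compounds. A small step is expected, a number 4 percentage points higher from compound 1 to compound 4 (within the scatter), not clearly beyond the scatter, with a slight lean upward. The estimate for compound 4 in this assay is 70%, ranging from 52% to 86%.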

Compound 4, a percentage reported as inhibition, at one concentration (the size of the read-out at that concentration, not a potency): 83%
Estimate against measurement, compound 4: 13 percentage points below; the range from low to high includes it.
By their numbers in this assay, from the lowest: compound 1; then compounds 2, 4 and 3 (each within the scatter of the next).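

For the compounds shown here, the step of a number 17 percentage points higher from compound 1 to compound 4 (beyond the scatter) in this assay is the first reading of a change in one place. It shows that the number responds to the aryl group at this nitrogen, with the rest of compound 1 held constant. No measurement at hand bears on why the number moves with this change.

From the compounds shown here alone, the bromine and the methoxy group enter together, so their separate contributions remain open. Also open, going by these compounds, is how a phenyl group carrying an amine or a carboxylic acid would read at this position.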